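Cytotoxicity notes on the shared-core amide series

The source may report more compounds than this note shows. Statements on the series, on what has been measured and on what is new or still open speak of the compounds shown alone.

Measured so far in an ADME assay on HELF cells (Homo sapiens) for cytotoxicity, with a stated time of 3 days; a lower number here means that less compound is tolerated, a higher number that more compound is tolerated:
compound 1, `CC(C)C[C@H](NC(=O)[C@]1(Cc2ccccc2)CCN1C(=O)OCc1ccccc1)C(N)=O`: 100000 nM
compound 2, `NC(=O)[C@H](CCC(=O)O)NC(=O)C1(Cc2ccccc2)CCN1C(=O)OCc1ccccc1`: > 100000 nM
compound 3, `CC(C)C[C@H](NC(=O)[C@@]1(Cc2ccccc2)CCN1C(=O)OCc1ccccc1)C(N)=O`: > 100000 nM

Among the measured compounds shown here, compound 1 gives the only number in this assay. Compound 2 shows a limit of this assay rather than a number. Compound 3 likewise shows only a limit. Compound 1 therefore stands as the one tolerated concentration that is fixed, while the rest of the set sits at the top of the measurable range.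

For the measured compounds named here, the single measured step, a number no lower from compound 1 to compound 3 (the limit leaves the size open), is of unreadable size because of the limit of > 100000 nM in this assay, at which 2 of the 3 values shown sit; the two compounds in it are related only through (the fact that compounds 1 and 3 differ only in the configuration as drawn). It says merely that the change in drawn configuration did not lower the tolerated concentration below what the assay reports.

Compound 4, `C[C@H](NC(=O)[C@]1(Cc2ccccc2)CCN1C(=O)OCc1ccccc1)C(=O)NC(C)(C)C`, is not yet measured. It differs from compound 1 by 1-((tert-butyl)carbamoyl)ethyl in place of 1-carbamoyl-3-methylbutyl on an amide-type nitrogen. Going by the values given here, no measured step touches this part of the structure, so nothing in the set gives a size for the step from compound 1. Among the compounds with values here, with the one number and both limits all sitting at the same level, the expected step is no change at the digits printed from compound 1 to compound 4 (within the scatter), within the scatter. Compound 4 is thus estimated at 100000 nM, between 50000 nM and 200000 nM, with a fair chance that only a limit is returned.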

Compound 4, minimum cytotoxic concentration: > 100000 nM
Compound 4 ended at the assay's limit (the forecaster's own chance of this, stated with the estimate: 50%); the middle value lies on the limit itself.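

On the amide-type nitrogen, 1-((tert-butyl)carbamoyl)ethyl in place of 1-carbamoyl-3-methylbutyl gives a number no lower from compound 1 to compound 4 (the limit leaves the size open) in this assay, and compound 4 shows > 100000 nM, which is a limit of the assay and not a number. Among the steps in the set, this is the only one that replaces the group at this place, since the earlier step changed only the configuration as drawn, so the exchange of these two groups is now seen not to lower the tolerated concentration. The size of the step cannot be read, and the reason lies in where the values of the set sit: the limit of > 100000 nM in this assay, at which 3 of the 4 values shown sit.

Left open is whether an amine, or a longer chain, in place of 1-((tert-butyl)carbamoyl)ethyl on the amide-type nitrogen would return a number rather than a limit in this assay. Also open, as far as these compounds go, is how far the change from 1-carbamoyl-3-methylbutyl to 1-((tert-butyl)carbamoyl)ethyl actually moves the tolerated concentration, which only a measurement beyond the present limit could fix.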